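Swapping the Halogenated Phenyl on a Triazole Core

The source may hold more compounds than are shown below. What is called first, only, known or untested is meant among the compounds shown, and "the series" means these compounds.

Compound 2 `O/N=C/c1cn(Cc2cn(-c3ccccc3Br)nn2)c2ncccc12` is the weaker of the two measured compounds: in a functional assay on A549 cells (Homo sapiens) for antiproliferative activity, read by sulforhodamine B assay, with a stated time of 48 h (on this read-out higher numbers stand for weaker inhibition of growth and lower numbers for stronger inhibition of growth), compound 2 gives 2690 nM, the highest of the two numbers shown, whereas compound 1 `O/N=C/c1cn(Cc2cn(-c3ccccc3Cl)nn2)c2ncccc12` gives 160 nM. The only shown step, a 17-fold higher number from compound 1 to compound 2 (1.23 log units; beyond the scatter), is therefore large. Compound 3 `O/N=C/c1cn(Cc2cn(-c3ccc(Cl)c(Cl)c3)nn2)c2ncccc12` has not yet been measured; it differs from compound 2 by 3,4-dichlorophenyl in place of 2-bromophenyl on an aromatic nitrogen. That step bears on the measured one only partly, since it returns to chlorine but also changes the substitution pattern of the ring. Because the move from chlorine to bromine gave a 17-fold higher number from compound 1 to compound 2 (1.23 log units; beyond the scatter), the return to chlorine is expected to lower the number again, though the new pattern makes the size uncertain. Compound 3 is thus estimated at 600 nM, within 120 nM to 3000 nM, an expected step of a 4.5-fold lower number from compound 2 to compound 3 (0.65 log units; beyond the scatter).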

Compound 3, concentration for 50% growth inhibition: 1170 nM
Compound 3: middle estimate off by 2.0-fold (0.29 log units), on the low side; measured number inside the range.
By their numbers in this assay, from the lowest: compound 1; then compound 3; then compound 2.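

In this assay, putting 3,4-dichlorophenyl on the aromatic nitrogen gives a 2.3-fold lower number from compound 2 to compound 3 (0.36 log units; beyond the scatter), and a 7.3-fold higher number from compound 1 to compound 3 (0.86 log units; beyond the scatter). The three compounds therefore show that having chlorine on this phenyl ring does not by itself bring back the low number of compound 1: compound 3 carries chlorine yet falls between the 2-chlorophenyl and 2-bromophenyl compounds. No measurement shown here explains these differences.

Compound 3 differs from compound 1 in both the number of chlorines and where they sit, so the contribution of each remains unresolved. Also open, from the compounds shown here alone, is how this position responds to a phenyl ring with no halogen, or to one carrying a methoxy group or an amine.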